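Cutting Back the Hydroxycarbamoyl Chain

A few compounds are considered here, and "the series" means these few. Any claim that something is new, unique, unknown or untested is made for them only; others in the source may bear on it.

In a functional assay on HepG2 cells (Homo sapiens) for inhibition, read by MTT assay, with a stated time of 72 h (on this read-out lower numbers stand for stronger inhibition and higher numbers for weaker inhibition), compound 1 `Nc1ncnc2c1c(-c1cnc3[nH]ccc3c1)nn2CCCCCC(=O)NO` gives 12900 nM and compound 2 `Nc1ncnc2c1c(-c1cnc3[nH]ccc3c1)nn2CCCCCCC(=O)NO` gives 10300 nM. For the measured compounds named here, compound 2 therefore stands level with compound 1, as the only measured step, a 1.3-fold lower number from compound 1 to compound 2 (0.10 log units; within the scatter), lies within the scatter. Compound 3 `Nc1ncnc2c1c(-c1cnc3[nH]ccc3c1)nn2CCC(=O)NO` has hydroxycarbamoyl in place of 4-(hydroxycarbamoyl)butyl, on a saturated chain carbon, two bonds along the chain from an aromatic nitrogen (hydroxycarbamoyl in place of 4-(hydroxycarbamoyl)butyl on a saturated chain carbon, two bonds along the chain from an aromatic nitrogen). This cut is larger than the chain change in the measured step, so that step offers limited guidance. A moderately higher number is expected, a 2.4-fold higher number from compound 2 to compound 3 (0.39 log units; beyond the scatter). Compound 3 is estimated at 25000 nM, with an expected range of 9000 nM to 70000 nM.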

Compound 3, half-maximal inhibitory concentration: > 150000 nM
Compound 3 ended at the assay's limit; the forecaster's own chance of this, stated with the estimate: 15%; middle value at least 6.0-fold (0.77 log units) away from the limit.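

The chain length at this position matters once the cut is large enough: compounds 1 and 2 stood level, but shortening the chain gives an at least 14-fold higher number from compound 2 to compound 3 (1.16 log units; beyond the scatter), and from the other long chain, an at least 11-fold higher number from compound 1 to compound 3 (1.06 log units; beyond the scatter). In this assay compound 3 gives a limit, not a number: the limit of > 150000 nM in this assay, at which 1 of the 3 values shown sits.

The compounds shown leave open at what chain length between these extremes the loss of inhibition sets in. They also leave open whether a longer chain, or a carboxylic acid in place of the hydroxycarbamoyl end, would change the picture.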